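Chloro to hydrogen on two cores: one measured, one expected

This account rests on a few compounds, and the source may have more. Where it says the series, first, only, none or still open, it means among the compounds named here.

Three compounds have been measured in a functional assay on U-87MG ATCC cells for antiproliferative activity against U-87 MG (Homo sapiens), read by MTT assay, with a stated time of 48 h, tested at 50 uM; a lower number here means a stronger effect, a higher number a weaker effect of the compound at the concentration tested:
compound 1 `COc1ccc(-c2nc(C)c(C(=O)CSc3nc(N)c(C#N)c(-c4ccc(Cl)cc4)n3)s2)cc1` gives 23.1%
compound 2 `COc1ccc(-c2nc(C)c(C(=O)CSc3nc(N)c(C#N)c(-c4ccccc4)n3)s2)cc1` gives 16.5%
compound 3 `Cc1nc(-c2ccccc2)sc1C(=O)CSc1nc(-c2cccc(Cl)c2)c(C#N)c(=O)[nH]1` gives 50.6%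

Compound 1 and compound 2 share a core and differ by hydrogen in place of chloro on an aromatic carbon. That change made a number 6.6 percentage points lower from compound 1 to compound 2 (within the scatter). Compound 3 stands on a different core; the difference between the two cores is not broken down here. Compound 4 `Cc1nc(-c2ccccc2)sc1C(=O)CSc1nc(-c2ccccc2)c(C#N)c(=O)[nH]1` differs from compound 3 by hydrogen in place of chloro on an aromatic carbon. For the measured compounds named here, this is the same kind of change as the one between compound 1 and compound 2, not the same change: there the place was para to a large group, here it is meta to a large group. Because the earlier step was a number 6.6 percentage points lower from compound 1 to compound 2 (within the scatter), a similarly small step is expected here, a number 4.6 percentage points lower from compound 3 to compound 4 (within the scatter). Compound 4 is estimated at 46%, expected to fall between 30% and 62%.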

Compound 4, a percentage reported as activity, at one concentration (the size of the read-out at that concentration, not a potency): 77.5%
Compound 4: the middle estimate sits 31.5 percentage points below what was measured; measured number outside the range, above it.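

In this assay, taking chloro off the core of compound 3 weakened the effect, a number 26.9 percentage points higher from compound 3 to compound 4 (beyond the scatter), so on this core the 3-chlorophenyl compound is the more active of the pair. The same kind of change therefore did not carry over from one core to the other: the same change on two cores in this assay, a number 6.6 percentage points lower (within the scatter) from compound 1 to compound 2 and a number 26.9 percentage points higher (beyond the scatter) from compound 3 to compound 4, 33.5 percentage points apart, beyond the scatter of two such steps

This does not show that the core alone sets the outcome, since the chloro sat para to a large group in compound 1 and meta to a large group in compound 3, and each core offers a single pair.

The compounds shown leave open how chloro para to a large group would behave on the core of compound 3. They also leave open how a fluoro or a bromo in place of that chloro would compare.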